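Benzyl for Phenyl on a Ring Nitrogen: Unknown Ground

The source may hold more compounds than are shown below. What is called first, only, known or untested is meant among the compounds shown, and "the series" means these compounds.

Compound 2 `CCCn1c(=O)[nH]c2nc(-c3ccc(S(=O)(=O)N4CCN(c5cccc(Cl)c5)CC4)cc3)[nH]c2c1=O` shares its core with compound 1 `CCCn1c(=O)[nH]c2nc(-c3ccc(S(=O)(=O)N4CCN(c5ccc(Br)cc5)CC4)cc3)[nH]c2c1=O`; the two differ only in the group carried on an amine nitrogen in a ring. In an assay on CHO cells for displacement of a labelled ligand from adenosine receptor A1 (Homo sapiens), read by scintillation counting, with a stated time of 90 min, in the presence of a further agent that is not named here (on this read-out lower numbers stand for stronger inhibition and higher numbers for weaker inhibition), compound 1 gives > 1000 nM, which is a limit of the assay rather than a number. In this assay compound 2 likewise gives > 1000 nM, again a limit. The step that the two limits leave unreadable from compound 1 to compound 2 therefore cannot be read, and compound 2 stands at the limit of > 1000 nM in this assay, at which 2 of the 2 values shown sit, together with its partner. Compound 3 `CCCn1c(=O)[nH]c2nc(-c3ccc(S(=O)(=O)N4CCN(Cc5cccc(Br)c5)CC4)cc3)[nH]c2c1=O` carries the next change: 3-bromobenzyl in place of 3-chlorophenyl on an amine nitrogen in a ring. No measured step bears on this change, and the two limits shown give no direction to lean on, so the step that the limit leaves unreadable from compound 2 to compound 3 is expected to be modest, with a real chance that this assay again reports only a limit. Compound 3 is estimated at 2000 nM in this assay, within 400 nM to 10000 nM.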

Compound 3, inhibition constant: 928 nM
Beside the measured number, compound 3's estimate is 2.2-fold (0.33 log units) above it; the measured number falls inside the stated range.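

In this assay compound 3 gives a true number, 928 nM, so 3-bromobenzyl is the only group shown on this amine nitrogen that yields a value rather than a limit. As far as these compounds go, the change can still be expressed only as a floor, an at least 1.0-fold lower number from compound 2 to compound 3 (0.03 log units; that floor lies within the scatter), and likewise an at least 1.0-fold lower number from compound 1 to compound 3 (0.03 log units; that floor lies within the scatter); both floors lie within the scatter, so no real gain is established and its size remains unknown. The step between the two earlier compounds cannot be read, and the limit they share remains the most common result in this small set: the limit of > 1000 nM in this assay, at which 2 of the 3 values shown sit.

A 3-bromophenyl or plain benzyl group on this nitrogen would be needed to separate the effect of the extra carbon link from that of the halogen. From the compounds shown here alone, how a small methyl group or a longer chain ending in a phenyl ring would read in this assay also remains open.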